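The compounds below may be only part of what the source reports. "The series", "measured", "known", "first", "only" and "open" are said of these compounds alone.

Working notes on the series. Compound 1 `CCCCC(=O)N1CCC(N2CCN(C(=O)c3c(NC(=O)NCC)sc4ccccc34)CC2)CC1` carries a butylcarbonyl on the ring nitrogen and has no result in a functional assay on HepG2 cells (Homo sapiens) for inhibition, read by scintillation counting, with a stated time of 2 h; on this read-out higher numbers stand for weaker inhibition and lower numbers for stronger inhibition: compound 1 stands at "not determined" (no result reported) there, so no number anchors this point of the series. The nearest measured neighbour is compound 2 `CCNC(=O)Nc1sc2ccccc2c1C(=O)N1CCN(C2CCN(C(=O)C(C)(C)C)CC2)CC1`; in this assay compound 2 gives 450 nM. Compound 3 `CCNC(=O)Nc1sc2ccccc2c1C(=O)N1CCN(C2CCN(C(=O)OC(C)(C)C(F)(F)F)CC2)CC1` differs from compound 1 by 1-methyl-1-(trifluoromethyl)ethoxy in place of butyl on a carbonyl carbon. Among the measured compounds shown here, with no measured pair of this kind, the step from compound 1 to compound 3 in this assay is expected to stay within the usual scatter, direction unclear. For compound 3 the value in this assay is estimated at 400 nM, expected between 100 nM and 1600 nM.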

Compound 3, half-maximal inhibitory concentration: 81 nM
Compound 3: the middle estimate sits 4.9-fold (0.69 log units) above what was measured, outside the stated range (below it).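

In this assay, a 5.6-fold lower number from compound 2 to compound 3 (0.74 log units; beyond the scatter) with 1-methyl-1-(trifluoromethyl)ethoxy in place of tert-butyl on a carbonyl carbon. This gives stronger inhibition and shows that the group at this position matters to the read-out. Nothing available bears on the reason for this shift.

Compound 1 has no number, so steps from it cannot be read. Also open, from the compounds shown here alone, is whether the shift follows the added oxygen or the fluorines, which tert-butoxy on the same carbonyl carbon would separate, and how an amine there would compare.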